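One Stereocentre Inverted in a Series at Its Limit

This account rests on a few compounds, and the source may have more. Where it says the series, first, only, none or still open, it means among the compounds named here.

In a functional assay on MCF7 cells (Homo sapiens) for cytotoxicity, read by MTT assay (on this read-out lower numbers stand for stronger inhibition and higher numbers for weaker inhibition), compound 2 `CC1(C)CCc2c([C@@H]3CCc4ccc(O)cc4O3)ccc(O)c2O1` gives > 100000 nM, which is a limit of the assay and not a number. Compound 1 `CC1(C)CCc2c(C3CCc4ccc(O)cc4O3)ccc(O)c2O1` gives > 100000 nM, likewise a limit. Compound 3 `CC1(C)C=Cc2c([C@H]3CCc4ccc(O)cc4O3)ccc(O)c2O1` gives > 100000 nM, again a limit. Compound 2 therefore offers no number to start from, only (the limit of > 100000 nM in this assay, at which 3 of the 3 values shown sit).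

Compound 4 `CC1(C)CCc2c([C@H]3CCc4ccc(O)cc4O3)ccc(O)c2O1` is the next to be read in this assay, and the change from compound 2 is this: the two compounds have the same atoms and bonds and differ only in configuration as drawn: 1 of 1 stereo elements differ; a stereocentre at a saturated ring carbon is drawn S in compound 2 and R in compound 4. Going by the values given here, only one measured step bears on it, since it touches the same stereocentre: a step that the two limits leave unreadable from compound 1 to compound 2. That step rests on (the fact that one of compounds 1 and 2 is drawn with a defined configuration and the other without, at the place where they differ), and it has no readable size to carry over. Among the compounds with values here, no compound measured so far has left the limit, whichever way this carbon is drawn in compounds 1 and 2.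

The expected step, a number no higher from compound 2 to compound 4 (the limit leaves the size open), is none beyond the scatter, and a further limit is the likeliest report. The estimate for compound 4 is 100000 nM, with an expected range from 50000 nM to 200000 nM.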

Compound 4, half-maximal inhibitory concentration: > 100000 nM
Compound 4 ended at the assay's limit; the forecaster's own chance of this, stated with the estimate: 85%; the middle value sits exactly at the limit.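

With compound 4 also at a limit of the assay, no step can be read from compound 2 to compound 4 or from compound 1 to compound 4. The compounds shown leave open whether the S and R configurations at this saturated ring carbon differ at all in this assay.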